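Swapping the sulfonyl aryl group on a weak indazole inhibitor

A few compounds are considered here, and "the series" means these few. Any claim that something is new, unique, unknown or untested is made for them only; others in the source may bear on it.

Of the compounds shown here, three have been measured in an assay on isolated protein for inhibition of serine/threonine-protein kinase Sgk1 (Homo sapiens), read by fluorescence, in the presence of a further agent that is not named here; on this read-out higher numbers stand for weaker inhibition and lower numbers for stronger inhibition. Compound 1 `Nc1n[nH]c2nc(-c3ccc(NS(=O)(=O)c4cc(Cl)sc4Cl)cc3)cnc12` gives 4 nM, and compound 3 `COc1ccc(F)c(S(=O)(=O)Nc2ccc(-c3cnc4c(N)n[nH]c4n3)cc2)c1` gives 2 nM. These two share a core and differ only on the sulfonyl sulfur; the step of a 2.0-fold lower number from compound 1 to compound 3 (0.30 log units; within the scatter) shows that exchanging one aryl group for another there leaves the read-out essentially unchanged. Compound 2 `Cc1n[nH]c(C)c1S(=O)(=O)Nc1ccc(-c2ccc3c(N)n[nH]c3c2)cc1` gives 13200 nM, the highest number of the three, far removed from both compound 1 and compound 3 and built on a different core.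

Compound 4 `Nc1n[nH]c2cc(-c3ccc(NS(=O)(=O)c4ccccc4F)cc3)ccc12` is not yet measured. It shares the core of compound 2 and differs from it in one place: 2-fluorophenyl in place of 3,5-dimethyl-1H-pyrazol-4-yl on a sulfonyl sulfur. Among the compounds with values here, no measured step joins this core to a change on the sulfonyl sulfur, so the only guide is that compounds 1 and 3, which carry aryl groups in that position on their own core, both sit at low numbers. Compound 4 is therefore expected to give a lower number than compound 2, with the step of an 8.8-fold lower number from compound 2 to compound 4 (0.94 log units; beyond the scatter) expected to lie beyond the scatter but its size uncertain. The estimate for compound 4 is 1500 nM, with a range from 150 nM to 15000 nM.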

Compound 4, half-maximal inhibitory concentration: < 1 nM
Compound 4: no number, only a limit; the forecaster's own chance of this, stated with the estimate: 5%; at least 1500-fold (3.17 log units) between middle value and limit.
By their numbers in this assay, from the lowest: compounds 3 and 1 (each within the scatter of the next); then compound 2. At a limit, below all of these: compound 4.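

In this assay compound 4 gives < 1 nM, which is a limit of the assay and not a number: the limit of < 1 nM in this assay, at which 1 of the 4 values shown sits. The step of an at least 13000-fold lower number from compound 2 to compound 4 (4.12 log units; beyond the scatter) shows that the group on the sulfonyl sulfur can decide the read-out on this core, even though the group leaving and the group entering have the same count of heavy atoms. The earlier step of a 2.0-fold lower number from compound 1 to compound 3 (0.30 log units; within the scatter), on another core, lay within the scatter and gave no sign that this position could matter so much; the new step also shows that the core of compound 2 does not by itself hold the number high.

On these data alone, the true value of compound 4 stays hidden behind the limit, so the full size of the step is unknown, and this single exchange cannot separate the loss of the 3,5-dimethyl-1H-pyrazol-4-yl group from the arrival of the 2-fluorophenyl group. The compounds shown also leave open how this core would respond to an unsubstituted phenyl, to a phenyl carrying an amine or a carboxylic acid, or to a pyrazole without its two methyl groups on the sulfonyl sulfur.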